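Swapping the dimethoxyphenyl arm for a chlorophenyl arm

A few compounds are considered here, and "the series" means these few. Any claim that something is new, unique, unknown or untested is made for them only; others in the source may bear on it.

Measured so far:
- compound 1, `COc1cccc(-c2cc(-c3cc(C(C)C)c(O)cc3C)[nH]c(=O)c2C#N)c1`, gives 22% in a functional assay for inhibition, tested at 20 ug/mL; on this read-out lower numbers stand for a weaker effect and higher numbers for a stronger effect at the one concentration tested
- compound 2, `COc1ccc(-c2cc(-c3cc(C(C)C)c(O)cc3C)[nH]c(=O)c2C#N)cc1OC`, gives 25% in this assay

Compound 2 holds the higher of the two numbers, but its nearest neighbour compound 1 sits close enough that the two values cannot be told apart. Within the data shown here, the single measured step, a number 3 percentage points higher from compound 1 to compound 2 (within the scatter), is the only guide to how the aryl arm of the shared core tolerates change, and it stayed within the scatter.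

Compound 3, `Cc1cc(O)c(C(C)C)cc1-c1cc(-c2ccccc2Cl)c(C#N)c(=O)[nH]1`, differs from compound 2 in one place: 2-chlorophenyl in place of 3,4-dimethoxyphenyl on an aromatic carbon. Among the measured compounds shown here, this change is larger than the one step measured, since both methoxy groups go and a chlorine arrives on a different position of the same ring. With only the flat step a number 3 percentage points higher from compound 1 to compound 2 (within the scatter) to lean on, no step beyond the scatter is expected; the estimate for compound 3 is 20%, with a range from 5% to 40%, corresponding to an expected step of a number 5 percentage points lower from compound 2 to compound 3 (within the scatter).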

Compound 3, a percentage reported as inhibition, at one concentration (the size of the read-out at that concentration, not a potency): 12%
Compound 3: middle estimate off by 8 percentage points, on the high side; the range from low to high includes it.
By their numbers in this assay, from the lowest: compounds 3, 1 and 2 (each within the scatter of the next, the first and the last beyond it).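

In this assay this position gives its first step beyond the scatter, with a number 13 percentage points lower from compound 2 to compound 3 (beyond the scatter) when 2-chlorophenyl replaces 3,4-dimethoxyphenyl on the aromatic carbon ortho to a cyano group. Replacing the 3-methoxyphenyl arm with the same 2-chlorophenyl gives a number 10 percentage points lower from compound 1 to compound 3 (within the scatter) and so stays at the edge of what can be told apart, which means only the change from the dimethoxy arm clearly registers here. No separate measurement bears on why the number moved.

Going by these compounds, both methoxy groups leave and a chlorine enters in one change, so the share of each in the step stays open. An amine or a carboxylic acid on this phenyl ring would show how the position takes groups of a different kind.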